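This account rests on a few compounds, and the source may have more. Where it says the series, first, only, none or still open, it means among the compounds named here.

Compound 1 `O=C1N/C(=C\c2ccc(Cl)cc2)C(=O)N1c1ccc(Cl)cc1` gives 35600 nM in a functional assay on NCI-H292 cells (Homo sapiens) for antiproliferative activity; a higher number here means a weaker inhibitor, a lower number a stronger inhibitor.
Compound 2 `COc1ccc(/C=C2\NC(=O)N(c3ccc(Cl)cc3)C2=O)cc1` gives 32100 nM in this assay.
Compound 3 `COc1cccc(N2C(=O)N/C(=C\c3ccc(O)cc3)C2=O)c1` gives > 200000 nM in this assay, which is a limit of the assay and not a number.

Compound 3 therefore stands at the limit of > 200000 nM in this assay, at which 1 of the 3 values shown sits, with no number of its own, while compounds 1 and 2 each give a number. Within the data shown here, the only measured step, a 1.1-fold lower number from compound 1 to compound 2 (0.04 log units; within the scatter), is within the scatter and concerns a small exchange. The change to compound 4 `O=C(Nc1ccc(Cl)cc1)c1cccc(N2C(=O)N/C(=C\c3ccc(O)cc3)C2=O)c1` is (4-chlorophenyl)carbamoyl in place of methoxy on an aromatic carbon, a much larger change than that measured step, so the measured data give no guide to its size or direction in this assay. Compound 4 is expected to give about 60000 nM, within a wide range from 8000 nM to 200000 nM. The step this estimate implies, an at least 3.3-fold lower number from compound 3 to compound 4 (0.52 log units; beyond the scatter), is itself only a rough expectation.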

Compound 4, half-maximal inhibitory concentration: 125000 nM
Compound 4: middle estimate off by 2.1-fold (0.32 log units), on the low side; the range from low to high includes it.
By their numbers in this assay, from the lowest: compounds 2 and 1 (each within the scatter of the next); then compound 4. At a limit, above all of these: compound 3.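

Placing the far larger (4-chlorophenyl)carbamoyl where methoxy stood, on this aromatic carbon, gives an at least 1.6-fold lower number from compound 3 to compound 4 (0.20 log units; that floor lies within the scatter) in this assay. This position therefore tolerates an added ring and an amide hydrogen while compound 4 still gives a number, though no firm gain can be claimed. The true size of the step stays unknown because compound 3 remains at a limit of the assay: the limit of > 200000 nM in this assay, at which 1 of the 4 values shown sits.

An amine or a carboxylic acid on this carbon remains an open case. So does the (4-chlorophenyl)carbamoyl group without its chlorine.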